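The compounds below may be only part of what the source reports. "The series", "measured", "known", "first", "only" and "open" are said of these compounds alone.

Measured so far:
- compound 1 `CCCCOC(=O)Nc1cccc2c1CN(C)CC2c1ccccc1`: 4 mg/kg
- compound 2 `CCNCC(=O)Nc1cccc2c1CN(C)CC2c1ccccc1`: 47 mg/kg

Going by the values given here, in a functional assay on the whole organism for inhibition, with Mus musculus as the target (on this read-out lower numbers stand for an effect already at smaller amounts and higher numbers for an effect only at larger amounts of compound), compound 2, at 47 mg/kg, holds the higher of the two numbers, and its only neighbour is compound 1 at 4 mg/kg. Next in the series is compound 3 `CCNCCC(=O)Nc1cccc2c1CN(C)CC2c1ccccc1`, where the change is (ethylamino)methyl in place of ethylamino on a saturated chain carbon bound to a carbonyl carbon.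

Among the compounds with values here, only one measured step bears on this place, a 12-fold higher number from compound 1 to compound 2 (1.07 log units; beyond the scatter). It is large and beyond the scatter, and it replaced butoxy with (ethylamino)methyl on a carbonyl carbon. The new change is a narrower one, since the ethylamino group stays in compound 3. Within the data shown here, no measured pair shows what this kind of chain extension does, so the direction remains open and the uncertainty is wide. The expected result in this assay is a small change, with a 1.3-fold lower number from compound 2 to compound 3 (0.13 log units; within the scatter) estimated to stay close to the scatter. For compound 3 the estimated value is 35 mg/kg, with an expected range from 12 mg/kg to 100 mg/kg.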

Compound 3, dose for half-maximal effect: > 200 mg/kg
Compound 3 gave a limit, no number; the forecaster's own chance of this, stated with the estimate: 10%; middle value at least 5.7-fold (0.75 log units) away from the limit.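

In this assay, compound 3 gives a limit and not a number: the limit of > 200 mg/kg in this assay, at which 1 of the 3 values shown sits.

With the ethylamino group kept, lengthening (ethylamino)methyl to 2-(ethylamino)ethyl gives an at least 4.2-fold higher number from compound 2 to compound 3 (0.62 log units; beyond the scatter), so this position responds to the chain alone, which the earlier step could not show because it replaced butoxy with a different group altogether. Measured against butoxy, the longer chain gives an at least 50-fold higher number from compound 1 to compound 3 (1.69 log units; beyond the scatter), so both ethylamino-bearing chains shown lie beyond the scatter from butoxy and in the same direction, with no compound here going against that.

The size of the chain-length effect stays unbounded on its upper side, since the step to compound 3 rests on a limit and a single lengthening shows only one point of the trend. Also open, going by these compounds, is whether the ethylamino group itself matters at this position, as a dimethylamino or piperidine group on the (ethylamino)methyl chain, or a shorter alkoxy group such as ethoxy in place of butoxy, would test how far the response depends on the group on the carbonyl carbon.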